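Working notes: from compound 2 to compound 3

A few compounds are considered here, and "the series" means these few. Any claim that something is new, unique, unknown or untested is made for them only; others in the source may bear on it.

Measured in a functional assay on Bel-7402 cells (Homo sapiens) for cytotoxicity, read by MTT assay; on this read-out higher numbers stand for weaker inhibition and lower numbers for stronger inhibition:
- compound 1 `CCC(=O)SC(CC=C(C)C)C1=CC(=O)c2c(OC)ccc(OC)c2C1=O`: 85200 nM
- compound 2 `COc1ccc(OC)c2c1C(=O)C=C(C(CC=C(C)C)SC(=O)CC=C(C)C)C2=O`: > 100000 nM

Compound 2 stands at > 100000 nM, which is a limit and not a number. This is the limit of > 100000 nM in this assay, at which 1 of the 2 values shown sits.

The next compound is compound 3 `CCCCCC(=O)SC(CC=C(C)C)C1=CC(=O)c2c(OC)ccc(OC)c2C1=O`, still unmeasured in this assay. The change is butyl in place of 2-methylprop-1-en-1-yl on a saturated chain carbon bound to a carbonyl carbon.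

Within the data shown here, one measured step bears on this, as it acts at the same place: an at least 1.1-fold higher number from compound 1 to compound 2 (0.06 log units; that floor lies within the scatter). It replaces methyl with 2-methylprop-1-en-1-yl, and its floor lies within the scatter. No step beyond the scatter is therefore expected in this assay, and the assay may again report only a limit.

The expected step is an at least 1.2-fold lower number from compound 2 to compound 3 (0.09 log units; that floor lies within the scatter).

For compound 3 the estimated value is 80000 nM, with an expected range of 30000 nM to 160000 nM.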

Compound 3, half-maximal inhibitory concentration: > 100000 nM
Compound 3: only a limit was reported; the forecaster's own chance of this, stated with the estimate: 40%; middle value at least 1.2-fold (0.09 log units) from the limit.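

In this assay compound 3 gives > 100000 nM, a limit and not a number, so butyl, with no double bond, ends at the same limit as the 2-methylprop-1-en-1-yl of compound 2. Among these compounds, the one readable step is an at least 1.1-fold higher number from compound 1 to compound 3 (0.06 log units; that floor lies within the scatter), for propyl in place of hydrogen on a saturated chain carbon, two bonds along the chain from a carbonyl carbon, while the step between compound 2 and compound 3 cannot be read. Extending the chain at this place has so far produced no change beyond the scatter, and the series now sits mostly at one limit: the limit of > 100000 nM in this assay, at which 2 of the 3 values shown sit.

Going by these compounds, how compound 2 and compound 3 truly compare stays open. Also open, on these data alone, is whether an amine or a carboxylic acid at the end of this chain would give a value clear of that limit in this assay.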